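The compounds below may be only part of what the source reports. "The series", "measured", "known", "first", "only" and "open" are said of these compounds alone.

Measured so far:

compound 1 `COc1ccc(C2N=C(SCc3ccc(Cl)cc3)NC(C)=C2C(=O)Nc2ccc(F)cc2)cc1OC`: 26.7%
compound 2 `COc1ccc(C2N=C(SCc3ccc(F)cc3)NC(C)=C2C(=O)Nc2ccc(F)cc2)cc1OC`: 21%
compound 3 `CC1=C(C(=O)Nc2ccc(Br)cc2)C(c2ccc(Cl)cc2Cl)N=C(SCc2ccc(Cl)cc2)N1`: 30.3%

All three were tested in a functional assay on the whole organism (artery, strain albino) with Rattus norvegicus as the target, with a stated time of 600 min, at a dose of 10 mg/kg by the oral route; on this read-out higher numbers stand for more inhibition at the one dose given (going by the name of the read-out) and lower numbers for less inhibition. Compound 1 and compound 2 share one core and differ in a single place: fluoro in place of chloro on an aromatic carbon. That change gave a number 5.7 percentage points lower from compound 1 to compound 2 (within the scatter), so the two numbers cannot be told apart with confidence. Compound 3 sits on a different core; the difference between the two cores is not broken down here. Its value in this assay stands near that of compound 1 and a little further from that of compound 2, but both gaps are within the scatter, so no ordering among the three can be claimed.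

Compound 4 `CC1=C(C(=O)Nc2ccc(Br)cc2)C(c2ccc(Cl)cc2Cl)N=C(SCc2ccc(F)cc2)N1` is not yet measured. It is made from compound 3 by the same change that turns compound 1 into compound 2: fluoro in place of chloro on an aromatic carbon. The place is described in the same words for both pairs, so this is the same change on another core.

Within the data shown here, the only guide to its effect is the one earlier step, a number 5.7 percentage points lower from compound 1 to compound 2 (within the scatter), which lay within the scatter. On that basis a step of similar size is expected here, a number 5.3 percentage points lower from compound 3 to compound 4 (within the scatter), but since the surrounding core differs, the expected range is kept wide. Compound 4 is therefore estimated at 25% in this assay, with the expected range running from 12% to 38%.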

Compound 4, a percentage reported as inhibition, in the whole organism at one dose (the size of the read-out at that dose, not a potency): 33.3%
Compound 4: middle estimate off by 8.3 percentage points, on the low side; the measured number falls inside the stated range.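

In this assay, putting 4-fluorobenzyl in place of 4-chlorobenzyl on the core of compound 3 gave a number 3 percentage points higher from compound 3 to compound 4 (within the scatter), so this pair cannot be told apart with confidence. On paper the two steps for this change point in opposite directions, but the gap between them is no larger than repeated measurements could produce: the same change on two cores in this assay, a number 5.7 percentage points lower (within the scatter) from compound 1 to compound 2 and a number 3 percentage points higher (within the scatter) from compound 3 to compound 4, 8.7 percentage points apart, within the scatter of two such steps. This gives no sign that the core alters the effect of swapping chloro for fluoro, but two small steps at a single dose do not prove that the change carries over unaltered, and a modest dependence on the core could still be hidden in the scatter.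

The compounds shown compare only chloro and fluoro at this place on the benzyl ring, so it remains open whether a clearly different group there, such as an amine or a carboxylic acid, would give a step large enough to stand out from the scatter. Among these compounds, also open is whether compound 3 and compound 4 would remain indistinguishable at other doses, as each has only one number here.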